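A few compounds are considered here, and "the series" means these few. Any claim that something is new, unique, unknown or untested is made for them only; others in the source may bear on it.

Compound 1 `CC(=O)Nc1ccc(-c2cn([C@@H]3CN[C@H](C(=O)Nc4ccc(Cl)c(C(F)(F)F)c4)C3)nn2)cn1` gives 33.6% in a functional assay on K562/Adr cells (Homo sapiens) for inhibition, read by MTT assay, with a stated time of 48 h, tested at 30 uM; on this read-out lower numbers stand for less inhibition and higher numbers for more inhibition at the one concentration tested (going by the name of the read-out).
Compound 2 `O=C(Nc1ccc(-c2cn([C@@H]3CN[C@H](C(=O)Nc4ccc(Cl)c(C(F)(F)F)c4)C3)nn2)cn1)C1CC1` gives 44.3% in this assay.
Compound 3 `CC(=O)Nc1nc2ccc(-c3cn([C@@H]4CN[C@H](C(=O)Nc5ccc(F)c(F)c5)C4)nn3)nc2s1` gives 38.4% in this assay.

Compound 1 and compound 2 share one core and differ in a single place: cyclopropyl in place of methyl on a carbonyl carbon. That one change made a number 10.7 percentage points higher from compound 1 to compound 2 (beyond the scatter). Compound 3 is built on a different core; the difference between the two cores is not broken down here. The values of compound 3 and compound 1 lie within the scatter of each other, and so do those of compound 3 and compound 2, so no order among them is claimed.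

Within the data shown here, compound 4 `O=C(Nc1nc2ccc(-c3cn([C@@H]4CN[C@H](C(=O)Nc5ccc(F)c(F)c5)C4)nn3)nc2s1)C1CC1` is the one compound not yet measured in this assay. It stands to compound 3 as compound 2 stands to compound 1: cyclopropyl in place of methyl on a carbonyl carbon. The place of the change reads the same in both pairs, word for word, so this is the same change carried onto a second core. Among the measured compounds shown here, only one earlier instance of it is known, and whether a second core answers the same way cannot be checked from three compounds. From the compounds shown here alone, the step expected from the change is a number 8.6 percentage points higher from compound 3 to compound 4 (within the scatter), set beside a number 10.7 percentage points higher from compound 1 to compound 2 (beyond the scatter); it is kept a little smaller and given a wide range because compound 3 starts from 38.4% on a core where the change is untested. For compound 4 the estimate in this assay is 47%, with a likely range from 35% to 59%.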

Compound 4, a percentage reported as inhibition, at one concentration (the size of the read-out at that concentration, not a potency): 29.5%
Beside the measured number, compound 4's estimate is 17.5 percentage points above it; measured number outside the range, below it.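

In this assay, putting cyclopropyl in place of methyl on a carbonyl carbon does not behave as a fixed step that can be carried from one core to the other: the same change on two cores in this assay, a number 10.7 percentage points higher (beyond the scatter) from compound 1 to compound 2 and a number 8.9 percentage points lower (within the scatter) from compound 3 to compound 4, 19.6 percentage points apart, beyond the scatter of two such steps On the core of compound 3 the change gave a number 8.9 percentage points lower from compound 3 to compound 4 (within the scatter), so on that core the pair cannot be told apart from ordinary repeat variation, while the gain on the core of compound 1 stands as measured. This does not show why the two cores answer differently, since they differ in more than one place and each is represented by a single pair, so nothing here singles out the part of the core that matters or shows that either result would hold for further pairs on the same core.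

The compounds shown carry only methyl and cyclopropyl on this carbonyl carbon, so it remains open how a longer chain such as propyl, or an amine in the same place, would read on either core. Also open, from the compounds shown here alone, is whether the two parts in which the cores differ matter separately, which a compound combining one part of each core could begin to answer.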